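A few compounds are considered here, and "the series" means these few. Any claim that something is new, unique, unknown or untested is made for them only; others in the source may bear on it.

Measured so far in a functional assay on NCI-H226 cells (Homo sapiens) for inhibition, read by sulforhodamine B assay, with a stated time of 48 h, tested at 100 uM; on this read-out lower numbers stand for a stronger effect and higher numbers for a weaker effect at the one concentration tested:
- compound 1 `COc1cc(Cl)cc(-c2nn(-c3cccc(NC(=O)Nc4ccc(Cl)c(Cl)c4)c3)cc2-c2ccncc2)c1` gives 2%
- compound 2 `COc1cc(Cl)cc(-c2nn(-c3cccc(NC(=O)Nc4cccc(C(F)(F)F)c4)c3)cc2-c2ccncc2)c1` gives -22%

Compound 2 stands lowest of these two numbers; its nearest neighbour is compound 1, and the step of a number 24 percentage points lower from compound 1 to compound 2 (beyond the scatter) lies beyond the scatter. Compound 3 `COc1cc(Cl)cc(-c2nn(-c3cccc(NC(=O)c4cccc(C(F)(F)F)c4)c3)cc2-c2ccncc2)c1` is not yet measured. It differs from compound 2 by 3-(trifluoromethyl)phenyl in place of (3-(trifluoromethyl)phenyl)amino on a carbonyl carbon. Within the data shown here, the one measured step changed the group on the amide-type nitrogen, not the carbonyl side, so no measured step bears directly on this change, and the size is uncertain. Compound 3 is expected to give -15% (range -45% to 15%), a step of a number 7 percentage points higher from compound 2 to compound 3 (within the scatter) that is not expected to exceed the scatter.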

Compound 3, a percentage reported as activity, at one concentration (the size of the read-out at that concentration, not a potency): 50%
Beside the measured number, compound 3's estimate is 65 percentage points below it; the measured number lies above the stated range.
By their numbers in this assay, from the lowest: compound 2; then compound 1; then compound 3.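

In this assay, the nitrogen on the carbonyl carbon proves important: 3-(trifluoromethyl)phenyl in place of (3-(trifluoromethyl)phenyl)amino gives a number 72 percentage points higher from compound 2 to compound 3 (beyond the scatter) and so a much weaker effect. The same group in place of (3,4-dichlorophenyl)amino gives a number 48 percentage points higher from compound 1 to compound 3 (beyond the scatter) and points the same way, so the weakening appears from both amino compounds, with none of the three going against it. Nothing available here explains this loss of effect. Going by these compounds, whether a methylamino linker, which keeps the nitrogen but replaces its hydrogen with a methyl group, would preserve the effect remains open.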